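Halogen swap on two sulfur-substituted anilines at alpha-2C

The source may hold more compounds than are shown below. What is called first, only, known or untested is meant among the compounds shown, and "the series" means these compounds.

Measured so far:
compound 1, `CS(=O)(=O)c1cc(F)ccc1NCC1=NCCN1`: 32%
compound 2, `CSc1ccc(F)cc1NCC1=NCCN1`: 97%
compound 3, `CSc1ccc(Cl)cc1NCC1=NCCN1`: 92%

In a functional assay on CHO cells for agonist activity at Alpha-2C adrenergic receptor (Homo sapiens) (a higher number here means a larger maximal response, a lower number a smaller maximal response), compound 1 gives 32%, the lowest of the three; compound 2 and compound 3 both lie far above it. Compound 4, `CS(=O)(=O)c1cc(Cl)ccc1NCC1=NCCN1`, is not yet measured. It differs from compound 1 by chloro in place of fluoro on an aromatic carbon. The same kind of change, (chloro in place of fluoro on an aromatic carbon), separates compound 2 from compound 3, with a step of a number 5 percentage points lower from compound 2 to compound 3 (within the scatter). The surroundings are not the same, however: in compound 1 the site is meta to a methylsulfonyl group and para to a group of 7 heavy atoms, whereas in compound 2 it is meta to a group of 7 heavy atoms and para to a methylsulfanyl group. How the core of compound 1 differs from that of compound 2 is not broken down here. Because a number 5 percentage points lower from compound 2 to compound 3 (within the scatter), a step of a number 2 percentage points lower from compound 1 to compound 4 (within the scatter) is expected from the same kind of change in this assay. Compound 4 is therefore estimated at 30%, between 15% and 50%.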

Compound 4, largest response reached (reported as maximum), in percent of the reference or control that the assay uses: 54%
For compound 4 the middle estimate is 24 percentage points below the measured one; measured number outside the range, above it.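

On the core of compound 1, chloro in place of fluoro on an aromatic carbon gives a number 22 percentage points higher from compound 1 to compound 4 (beyond the scatter). In this assay, the size of this step does not carry over from one core to the other: the same change on two cores in this assay, a number 5 percentage points lower (within the scatter) from compound 2 to compound 3 and a number 22 percentage points higher (beyond the scatter) from compound 1 to compound 4, 27 percentage points apart, beyond the scatter of two such steps Two pairs give no rule for other cores, and they do not show which difference between the two cores goes with the gap.

The compounds shown leave open how the maximal response moves with bromo or methoxy in place of the halogen. They also leave open what a methylsulfinyl group would give in place of the methylsulfonyl or methylsulfanyl group.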